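Compound 3 to compound 4: a 3-oxopiperazin-1-yl swap

The source may hold more compounds than are shown below. What is called first, only, known or untested is meant among the compounds shown, and "the series" means these compounds.

In an ADME assay on microsomes from liver (Mus musculus) for metabolic stability, read by LC-MS, using NADPH, with stated times of 10 min and 30 min, tested at 1 uM (on this read-out higher numbers stand for fast clearance and lower numbers for slow clearance), compound 3 (`COC(=O)C1=C(CN2CC3CC2CO3)NC(c2nccs2)=NC1(C)c1ccc(F)cc1`) gives 84 mL/min/kg. Its number sits close to those of the two other measured compounds: compound 2 (`COC(=O)C1=C(CN2CCCCC2)NC(c2nccs2)=NC1(C)c1ccc(F)cc1`) gives 88 mL/min/kg and compound 1 (`COC(=O)C1=C(C)NC(c2nccs2)=NC1(C)c1ccc(C#N)cc1`) gives 75 mL/min/kg. All three lie within the scatter of one another, so compound 3 holds no distinct rank among them.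

Compound 4 (`COC(=O)C1=C(CN2CCNC(=O)C2)NC(c2nccs2)=NC1(C)c1ccc(F)cc1`) comes from compound 3 by a single structural change: a group of 7 heavy atoms (4 carbon, 2 nitrogen, 1 oxygen; one six-membered non-aromatic ring with 2 hetero atoms) in place of a group of 7 heavy atoms (5 carbon, 1 nitrogen, 1 oxygen; 2 five-membered non-aromatic rings with 1 hetero atom each), on a saturated chain carbon bound to a double-bonded ring carbon. The entering group is 3-oxopiperazin-1-yl.

For the measured compounds named here, only one measured step bears on this place in the molecule: a 1.0-fold lower number from compound 2 to compound 3 (0.02 log units; within the scatter). Going by the values given here, that step lies within the scatter, which suggests that the one swap tested here left the number in this assay unmoved. Among the compounds with values here, it is thin evidence, however, as no measured compound carries the 3-oxopiperazin-1-yl group. The range is therefore kept wide, and wider towards lower numbers.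

No shift beyond the scatter is expected, and the estimated move, a modest one towards a lower number, is a 1.3-fold lower number from compound 3 to compound 4 (0.10 log units; within the scatter). For compound 4 the expected value is 66 mL/min/kg, with an estimated range from 36 mL/min/kg to 95 mL/min/kg.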

Compound 4, clearance: 81 mL/min/kg
The estimate for compound 4 lay 1.2-fold (0.09 log units) below the measured number; the range from low to high includes it.
By their numbers in this assay, from the lowest: compounds 1, 4, 3 and 2 (each within the scatter of the next).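

In this assay, the 3-oxopiperazin-1-yl group gives a reading within the scatter of both other groups measured on the saturated chain carbon bound to a double-bonded ring carbon, with a 1.0-fold lower number from compound 3 to compound 4 (0.02 log units; within the scatter) and a 1.1-fold lower number from compound 2 to compound 4 (0.04 log units; within the scatter). Compounds 2, 3 and 4 therefore extend the earlier single comparison to three different ring groups at this place, and none of the listed steps among them lies beyond the scatter, even though 3-oxopiperazin-1-yl brings a hydrogen-bond donor and a double bond outside aromatic rings that the group it replaces does not have. Nothing available here explains this reading.

What the compounds shown leave open is whether this insensitivity holds only for ring groups, since an open-chain dimethylamino group or a carboxylic acid on the same carbon could still give a reading beyond the scatter. Going by these compounds, it also remains open whether a different group on this carbon would behave the same way with the nitrile in place of the fluorine on the shared core, as that pairing cannot be read from these compounds.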